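The source may hold more compounds than are shown below. What is called first, only, known or untested is meant among the compounds shown, and "the series" means these compounds.

The measured compounds:

compound 1, `CCc1nc(Cl)c2n1CCN([C@@H](C(=O)NC)c1ccccc1)[C@H]2CCc1cccc(C(F)(F)F)c1`, which in a functional assay on CHO cells for antagonist activity at Orexin/Hypocretin receptor type 1 (Homo sapiens), read by FLIPR and calcium flux (on this read-out lower numbers stand for stronger inhibition and higher numbers for weaker inhibition), gives 72 nM
compound 2, `CCc1nc(Cl)c2n1CCN([C@@H](C(=O)NC)c1ccccc1)[C@H]2CCc1ccc(C(F)(F)F)cc1F`, which gives 45 nM
compound 3, `CNC(=O)[C@@H](c1ccccc1)N1CCn2c(C3CC3)nc(Cl)c2[C@@H]1CCc1cccc(C(F)(F)F)c1`, which gives 91 nM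

Compound 3 has the highest number of the three. Its gap to compound 1 is small, a 1.3-fold higher number from compound 1 to compound 3 (0.10 log units; within the scatter), and its gap to compound 2 is wider, beyond the scatter, though still modest.

Compound 4, `CNC(=O)[C@@H](c1ccccc1)N1CCn2c(C3CC3)nc(Cl)c2[C@@H]1CCc1ccc(OC(F)F)c(F)c1`, is built from compound 3 by replacing the aromatic ring at the end of the chain: 4-(difluoromethoxy)-3-fluorophenyl in place of 3-(trifluoromethyl)phenyl on a saturated chain carbon, two bonds along the chain from a saturated ring carbon. Within the data shown here, one measured step bears on this place: a 1.6-fold lower number from compound 1 to compound 2 (0.20 log units; within the scatter), a swap of one fluorinated phenyl ring for another at the same place on the chain, which moved the number only a little. The ring entering compound 4 carries a difluoromethoxy group and a fluorine instead, so that earlier step is only a loose guide. The expectation in this assay is therefore a step of no more than scatter size, leaning toward a slightly lower number: the expected step is a 1.3-fold lower number from compound 3 to compound 4 (0.11 log units; within the scatter). Compound 4 is estimated at 70 nM, with a likely range from 25 nM to 200 nM.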

Compound 4, half-maximal inhibitory concentration: 170 nM
Estimate against measurement, compound 4: 2.4-fold (0.39 log units) below; the measured number falls inside the stated range.
By their numbers in this assay, from the lowest: compounds 2, 1, 3 and 4 (each within the scatter of the next, the first and the last beyond it).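

In this assay, replacing 3-(trifluoromethyl)phenyl with 4-(difluoromethoxy)-3-fluorophenyl gives a 1.9-fold higher number from compound 3 to compound 4 (0.27 log units; within the scatter), so a ring that brings an oxygen and a hydrogen-bond acceptor can stand at the end of this chain without a step beyond the scatter. Alongside a 1.6-fold lower number from compound 1 to compound 2 (0.20 log units; within the scatter), this is a second ring swap at the same place, now with cyclopropyl rather than ethyl on the aromatic carbon, and neither of the two swaps shown separates clearly from the scatter. The data shown offer no explanation for the size or direction of this step.

All the rings shown at this place are phenyl rings carrying fluorinated groups, so it remains open how the read-out would respond to a ring bearing an amine or a carboxylic acid, or to a longer chain between the core and the ring. Among these compounds, each ring also appears with only one of the two groups on the aromatic carbon, so it is unknown whether the 2-fluoro-4-(trifluoromethyl)phenyl and 4-(difluoromethoxy)-3-fluorophenyl rings would behave the same way with the other group.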